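Oxolan-2-yl in place of cyclohexyl on a sulfonyl chain

This account rests on a few compounds, and the source may have more. Where it says the series, first, only, none or still open, it means among the compounds named here.

Measured in a functional assay, read by fluorescence and spectrophotometry, with a stated time of 1 h (a higher number here means that more compound is needed for the effect, a lower number that less compound is needed), so far:
- compound 1 `O=S(=O)(/C=C/c1ccc(O)c(O)c1)CC1CCCCC1` gives 7500 nM
- compound 2 `CCCCCS(=O)(=O)/C=C/c1ccc(O)c(O)c1` gives 8100 nM

Compound 1 and compound 2 stand within the scatter of each other, so neither can be ranked above the other. Compound 3 `O=S(=O)(/C=C/c1ccc(O)c(O)c1)CC1CCCO1` has not yet been measured. It keeps the core of compound 1 but has oxolan-2-yl in place of cyclohexyl on a saturated chain carbon bound to a sulfonyl sulfur. For the measured compounds named here, one measured step bears on this place, butyl in place of cyclohexyl (a 1.1-fold higher number from compound 1 to compound 2 (0.03 log units; within the scatter)). That step stayed within the scatter, a hint that the group can vary with little change in this assay. Going by the values given here, it is only one step, however, and neither measured compound has a hetero atom in this group, so a shift in either direction remains possible. The expected outcome is no change beyond the scatter (a 1.2-fold higher number from compound 1 to compound 3 (0.08 log units; within the scatter)). The estimate for compound 3 is 9000 nM (expected range 3500 nM to 23000 nM).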

Compound 3, half-maximal effective concentration: 10500 nM
Compound 3: the middle estimate sits 1.2-fold (0.07 log units) below what was measured; the range from low to high includes it.
By their numbers in this assay, from the lowest: compounds 1, 2 and 3 (each within the scatter of the next).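

In this assay, oxolan-2-yl in place of cyclohexyl gives a 1.4-fold higher number from compound 1 to compound 3 (0.15 log units; within the scatter), and the same group in place of butyl gives a 1.3-fold higher number from compound 2 to compound 3 (0.11 log units; within the scatter). Until now, this position had been probed only with groups made entirely of carbon and hydrogen, so these steps add something new: on a saturated chain carbon bound to a sulfonyl sulfur, a five-membered ring containing an oxygen and a hydrogen-bond acceptor also leaves the number within the scatter, and the open chain, the carbon ring and the oxygen ring cannot be ranked against one another here. Nothing measured here gives a reason for this flat result.

From the compounds shown here alone, all three groups are uncharged, so it remains open whether an amine or a carboxylic acid at this place would move the number beyond the scatter, or whether this position simply has little influence in this assay. All three compounds also share the same core, so whether the group would matter as little on a changed core is still unanswered.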